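The compounds below may be only part of what the source reports. "The series", "measured", "known", "first", "only" and "open" are said of these compounds alone.

Working notes on the series. Three measured compounds share a core: compound 1 `CC(C)=CC[C@H](OC(=O)C=C(C)C)C1=CC(=O)c2c(O)ccc(O)c2C1=O`, compound 2 `COc1ccc(O)c2c1C(=O)C=C(CCC=C(C)C)C2=O` and compound 3 `COc1ccc(O)c2c1C(=O)C(CCC=C(C)C)=CC2=O`. In a functional assay on LNCaP cells (Homo sapiens) for cytotoxicity, read by MTT assay, with a stated time of 48 h (on this read-out higher numbers stand for weaker inhibition and lower numbers for stronger inhibition), compound 1 gives 11300 nM, compound 2 gives 10900 nM and compound 3 gives 11100 nM. Compound 2 carries the lowest of the three numbers, but compound 3 and compound 1 both sit within the scatter of it, so nothing separates the three. Compound 4 `COc1ccc(O)c2c1C(=O)C=C([C@H](CC=C(C)C)OC(C)=O)C2=O` is not yet measured in this assay. It differs from compound 2 by acetoxy in place of hydrogen on a saturated chain carbon bound to a double-bonded ring carbon and a saturated chain carbon. Among the measured compounds shown here, no measured pair shows this change, so the step of a 1.0-fold higher number from compound 2 to compound 4 (0.00 log units; within the scatter) is expected to fall within the scatter, given that compound 1 with its own ester at 11300 nM is not set apart from compound 2. Compound 4 is estimated at 11000 nM, in the range 5000 nM to 25000 nM.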

Compound 4, half-maximal inhibitory concentration: 11000 nM
Compound 4: middle estimate and measured number agree at the digits printed; the measured number falls inside the stated range.
By their numbers in this assay, from the lowest: compounds 2, 4, 3 and 1 (each within the scatter of the next).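

In this assay, acetoxy in place of hydrogen on a saturated chain carbon bound to a double-bonded ring carbon and a saturated chain carbon gives a 1.0-fold higher number from compound 2 to compound 4 (0.00 log units; within the scatter). Among the compounds shown here, this is the first single-place step, and it shows that this position carries the ester with no readable shift in the number. No available evidence bears on this result.

On these data alone, whether an amine, a carboxylic acid or a longer acyl chain at this carbon would move the number stays open. So does whether any change at this position can separate a compound from the others.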